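Acetamido enters after two readings close to zero

This account rests on a few compounds, and the source may have more. Where it says the series, first, only, none or still open, it means among the compounds named here.

Going by the values given here, in an ADME assay on cells (Hepatocyte, Homo sapiens) for metabolic stability, with a stated time of 30 min (a higher number here means that more of the compound is left, a lower number that less of the compound is left), compound 2 (`O=C(OC1CCC(CN2CCN(c3cc(=O)c4cc(C(F)(F)F)cc([N+](=O)[O-])c4s3)CC2)CC1)C1CCCCC1`) gives 2.8% remaining and compound 1 (`CC(=O)OC1CCC(CN2CCN(c3cc(=O)c4cc(C(F)(F)F)cc([N+](=O)[O-])c4s3)CC2)CC1`) gives 0% remaining, so compound 2 stands within the scatter of the only other measured value. Compound 3 (`CC(=O)NC1CCC(CN2CCN(c3cc(=O)c4cc(C(F)(F)F)cc([N+](=O)[O-])c4s3)CC2)CC1`) carries acetamido in place of (cyclohexylcarbonyl)oxy on a saturated ring carbon. Among the compounds with values here, the one measured step is a number 2.8 percentage points higher from compound 1 to compound 2 (within the scatter) and it places cyclohexyl in place of methyl on a carbonyl carbon, so it bears on this change only weakly. Within the data shown here, no measured compound carries acetamido, and the data therefore give no direct guide to this exchange. Both measured values lie close to the bottom of the scale, which leaves room mainly for a rise. No step beyond the scatter is expected in this assay and the estimated step is a number 5.2 percentage points higher from compound 2 to compound 3 (within the scatter) with a slight rise. For compound 3 the estimated value is 8% with an expected range from 0% to 28% in this measurement.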

Compound 3, percent of the compound remaining: 86.8%
Estimate against measurement, compound 3: 78.8 percentage points below; the whole stated range lies below it.
By their numbers in this assay, from the lowest: compounds 1 and 2 (each within the scatter of the next); then compound 3.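

At this position on a saturated ring carbon, the attached group can move the result in this assay far more than the earlier change did: the exchange of (cyclohexylcarbonyl)oxy for acetamido gives a number 84 percentage points higher from compound 2 to compound 3 (beyond the scatter). The closer comparison is acetamido in place of acetoxy, which keeps the acetyl part and gives a number 86.8 percentage points higher from compound 1 to compound 3 (beyond the scatter), whereas changing methyl to cyclohexyl on the carbonyl carbon gave only a number 2.8 percentage points higher from compound 1 to compound 2 (within the scatter). Nothing shown here explains why the acetamido compound stands so much higher.

The compounds shown leave open whether a cyclohexylcarbonylamino group at this position would stay as high as acetamido. They also leave open how a simple amine, a carboxylic acid or an N-methylacetamido group would read here.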